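Chloro substitution on the pendant aryl ring, A2b displacement

This account rests on a few compounds, and the source may have more. Where it says the series, first, only, none or still open, it means among the compounds named here.

Measured so far:
compound 1 `Cn1cnc2c(N3CCCCC3)nc(-c3ccccc3O)nc21` gives 30.2% in an assay on cells for displacement of a labelled ligand from adenosine receptor A2b (Homo sapiens), read by scintillation counting and radioligand binding, with a stated time of 30 min, tested at 10 uM; on this read-out lower numbers stand for less inhibition and higher numbers for more inhibition at the one concentration tested (going by the name of the read-out)
compound 2 `CN1CCN(c2nc(-c3ccc(Cl)cc3)nc3[nH]cnc23)CC1` gives 6.2%
compound 3 `CN1CCN(c2nc(-c3ccc(Cl)c(Cl)c3)nc3[nH]cnc23)CC1` gives 24.1%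

Compound 1 stands above compound 2 by a gap beyond the scatter; its gap to compound 3 is within the scatter, so no order between those two is claimed. Compound 4 `Cn1cnc2c(N3CCCCC3)nc(-c3cc(Cl)ccc3Cl)nc21` differs from compound 1 by 2,5-dichlorophenyl in place of 2-hydroxyphenyl on an aromatic carbon. Within the data shown here, the only measured step that bears on it is a number 17.9 percentage points higher from compound 2 to compound 3 (beyond the scatter), a chloro entering in place of hydrogen on a different core; it points upward, modestly. Among the measured compounds shown here, the loss of the hydroxyl has no measured counterpart, so its effect is unknown. For compound 4 an estimated step of a number 5.8 percentage points higher from compound 1 to compound 4 (within the scatter) in this assay is expected, upward or none beyond the scatter. Compound 4 is thus estimated at 36%, within 15% to 57%.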

Compound 4, a percentage reported as inhibition, at one concentration (the size of the read-out at that concentration, not a potency): 31%
Beside the measured number, compound 4's estimate is 5 percentage points above it, and the stated range covers the measured number.
By their numbers in this assay, from the lowest: compound 2; then compounds 3, 1 and 4 (each within the scatter of the next).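

On the core of compound 1, the aromatic carbon between two ring nitrogen atoms accepts 2,5-dichlorophenyl in place of 2-hydroxyphenyl with a number 0.8 percentage points higher from compound 1 to compound 4 (within the scatter) in this assay. The hydrogen-bond donor and acceptor of 2-hydroxyphenyl are absent from the entering group, yet the read-out shows no change beyond the scatter. No available measurement accounts for this result.

Going by these compounds, the step combines the loss of the hydroxyl with the entry of two chloro groups, so their separate contributions remain open. Also open, on these data alone, is how 2-methoxyphenyl or 2-aminophenyl would read at this position.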